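Aryl swap on the ring nitrogen of compound 3

This account rests on a few compounds, and the source may have more. Where it says the series, first, only, none or still open, it means among the compounds named here.

compound 1 `Cc1ccc(Nc2nc(SCc3cn(CC(=O)NC(=O)Nc4ccccn4)nn3)nc(-c3ccc(C(C)C)cc3)c2C#N)cc1`: > 64000 nM
compound 2 `Cc1cccc(Nc2nc(SCc3cn(CC(=O)NC(=O)Nc4ccccn4)nn3)nc(-c3ccc(C(C)C)cc3)c2C#N)c1`: > 64000 nM
compound 3 `COc1cc(-c2nc(SCc3cn(CC(=O)NC(=O)Nc4ccccn4)nn3)nc(Nc3ccc(C)cc3)c2C#N)cc(OC)c1OC`: 21000 nM

In a functional assay on MCF7 cells (Homo sapiens) for inhibition, read by MTT assay, with a stated time of 72 h (on this read-out lower numbers stand for stronger inhibition and higher numbers for weaker inhibition), compound 1 gives only a limit, > 64000 nM. Compound 2 also gives only a limit, > 64000 nM. For the measured compounds named here, compound 3 gives 21000 nM in this assay and so stands as the only number in the set; the two remaining values sit at the limit of > 64000 nM in this assay, at which 2 of the 3 values shown sit. Going by the values given here, the one readable step is an at least 3.0-fold lower number from compound 1 to compound 3 (0.48 log units; beyond the scatter). The step that the two limits leave unreadable from compound 1 to compound 2 changes the aryl group on the same nitrogen that is varied next, but both ends of it are limits, so its size cannot be read.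

Compound 4 `COc1cc(-c2nc(SCc3cn(CC(=O)NC(=O)Nc4ccccn4)nn3)nc(Nc3cccc(Cl)c3)c2C#N)cc(OC)c1OC` differs from compound 3 by 3-chlorophenyl in place of 4-methylphenyl on a nitrogen on an aromatic ring. Among the compounds with values here, no measured step introduces a chlorine, and the only step at this nitrogen is unreadable, so there is no measured size to carry over. The expectation for the step from compound 3 to compound 4 in this assay is therefore no change beyond the scatter, a 1.1-fold lower number from compound 3 to compound 4 (0.02 log units; within the scatter). Compound 4 is estimated at 20000 nM in this assay, with a range from 7000 nM to 60000 nM, and a real chance that only a limit is reported.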

Compound 4, half-maximal inhibitory concentration: 24000 nM
Estimate against measurement, compound 4: 1.2-fold (0.08 log units) below; the range from low to high includes it.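

In this assay, for the compounds shown here, the first readable step at this nitrogen is a 1.1-fold higher number from compound 3 to compound 4 (0.06 log units; within the scatter), so replacing 4-methylphenyl with 3-chlorophenyl, with the 3,4,5-trimethoxyphenyl group held in place, gives no change beyond the scatter. This single swap alters both the substituent on the aryl ring and its printed ring number, and the two values still lie within the scatter of each other, so this pair shows no sensitivity to the change at this nitrogen. The earlier step at the same nitrogen, which joins two compounds carrying 4-isopropylphenyl, cannot be read, and the assay limit leaves those compounds without numbers: the limit of > 64000 nM in this assay, at which 2 of the 4 values shown sit.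

The pair cannot separate the effect of the substituent from that of its ring number, and a 4-chlorophenyl or 3-methylphenyl group on the nitrogen of the compound 3 scaffold would be needed to do so. It also leaves open whether the flat response holds for groups of a different kind at this nitrogen, such as an aminophenyl, a carboxyphenyl or a longer alkyl chain in place of the aryl ring.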